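The compounds below may be only part of what the source reports. "The series", "measured", "known", "first", "only" and "open" are said of these compounds alone.

Measured so far in an assay on cells with melanin-concentrating hormone receptor 1 (Homo sapiens) as the target, read by radioligand binding; on this read-out lower numbers stand for stronger inhibition and higher numbers for weaker inhibition:
compound 1 `CCCC(C)Oc1cccc2ccc(N)nc12`: 105 nM
compound 2 `CC(C)C(C)Oc1cccc2ccc(N)nc12`: 199 nM
compound 3 `Nc1ccc2cccc(OCC3CCC3)c2n1`: 432 nM

Compound 3 carries the highest of these three numbers. Its nearest neighbour is compound 2, separated from it by a 2.2-fold higher number from compound 2 to compound 3 (0.34 log units; beyond the scatter); compound 1 lies further off, by a 4.1-fold higher number from compound 1 to compound 3 (0.61 log units; beyond the scatter). Between compound 1 and compound 2 the step is only a 1.9-fold higher number from compound 1 to compound 2 (0.28 log units; within the scatter).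

Compound 4 `Nc1ccc2cccc(OCCC3CC3)c2n1` has not yet been measured. It differs from compound 3 by cyclopropylmethyl in place of cyclobutyl on a saturated chain carbon bound to an oxygen on an aromatic ring. The two compounds are built from the same atoms, joined differently, so nothing is added or removed. Within the data shown here, no measured step compares one ring size with another: the two steps that end at compound 3 each replace a branched chain with cyclobutylmethyl, and each raised the number modestly, but they say nothing about trading a four-membered ring for a three-membered one on a longer chain. Among the measured compounds shown here, with no step that bears directly on this change, the expectation for compound 4 is a step of a 1.2-fold lower number from compound 3 to compound 4 (0.09 log units; within the scatter) in this assay, a number close to that of compound 3. Compound 4 is estimated at 350 nM, with a range from 150 nM to 800 nM.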

Compound 4, half-maximal inhibitory concentration: 492 nM
For compound 4 the middle estimate is 1.4-fold (0.15 log units) below the measured one; low and high end bracket the measured number.
By their numbers in this assay, from the lowest: compounds 1 and 2 (each within the scatter of the next); then compounds 3 and 4 (each within the scatter of the next).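

In this assay, cyclobutylmethyl and 2-cyclopropylethyl on the oxygen on an aromatic ring cannot be told apart (a 1.1-fold higher number from compound 3 to compound 4 (0.06 log units; within the scatter)), so swapping the four-membered ring for a three-membered one on a longer chain, with the same atoms, makes no measurable difference here. Compound 4 also keeps the gap to the branched chains of the earlier compounds (a 2.5-fold higher number from compound 2 to compound 4 (0.39 log units; beyond the scatter); a 4.7-fold higher number from compound 1 to compound 4 (0.67 log units; beyond the scatter)), so compounds 3 and 4 both give higher numbers than compounds 1 and 2, with no exception among these four. No measurement at hand accounts for this gap.

From the compounds shown here alone, whether the higher numbers go with the rings or with the lack of a branch on the carbon bound to the oxygen stays open. Also open, going by these compounds, is how a longer chain, or an amine at the end of the chain, would read at this position.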